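The source may hold more compounds than are shown below. What is called first, only, known or untested is meant among the compounds shown, and "the series" means these compounds.

Measured so far:
Compound 1, `C=CC1=C(C(=O)O)C(c2ccc(F)cc2)OC1`, in a functional assay on HeLa cells (Homo sapiens) for cytotoxicity, read by MTT assay, with a stated time of 24 h (a higher number here means a weaker inhibitor, a lower number a stronger inhibitor), gives 67400 nM.
Compound 2, `C=CC1=C(C(=O)NC2CCCCC2)C(c2ccc(F)cc2)OC1`, in this assay gives > 100000 nM.

The value for compound 2 is a limit of this assay and not a number; compound 2 is the one of the two that sits at the limit of > 100000 nM in this assay, at which 1 of the 2 values shown sits. Among the measured compounds shown here, the only measured step is an at least 1.4-fold higher number from compound 1 to compound 2 (0.17 log units; that floor lies within the scatter); its floor lies within the scatter, so the amide of compound 2 is no better than the acid of compound 1 and may be far weaker.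

Compound 3, `C=CC1=C(C(=O)NCc2ccccc2)C(c2ccc(F)cc2)OC1`, carries benzyl in place of cyclohexyl on an amide-type nitrogen. For the measured compounds named here, no measured step bears on this change directly: the one step on record concerns the replacement of hydroxy by cyclohexylamino, not one amide substituent against another. What is known of compound 2 is a limit, so the expectation for compound 3 rests on that limit alone. A step that the limit leaves unreadable from compound 2 to compound 3 is expected, that is, none beyond the scatter, with a fair chance that compound 3 again returns only a limit. Compound 3 is therefore estimated at 120000 nM in this assay, within 40000 nM to 400000 nM.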

Compound 3, half-maximal inhibitory concentration: > 100000 nM
Compound 3: no number, only a limit; the forecaster's own chance of this, stated with the estimate: 60%; the middle value does not contradict the limit.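

In this assay the amide-type nitrogen has now carried two different groups, cyclohexyl and benzyl, and compound 2 and compound 3 both end at a limit of the assay and not at a number: the limit of > 100000 nM in this assay, at which 2 of the 3 values shown sit.

Among the compounds shown here, the change from the acid to the benzyl amide reads as an at least 1.4-fold higher number from compound 1 to compound 3 (0.17 log units; that floor lies within the scatter), which matches what the cyclohexylamino change showed: neither amide gives a measured improvement on the acid, and compound 1 still holds the only true number. The step between the two amides cannot be read, so the aromatic benzyl and the non-aromatic cyclohexyl cannot be told apart here, and nothing in this assay yet ranks one amide substituent against the other.

On these data alone, how far the two amides lie past the limit stays open, and so does whether either truly differs from compound 1, since both floors lie within the scatter. As far as these compounds go, it is also open whether a methyl ester on the carbonyl carbon, or an amide carrying an amine on a short chain, would return a number in this assay.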